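A few compounds are considered here, and "the series" means these few. Any claim that something is new, unique, unknown or untested is made for them only; others in the source may bear on it.

Among the measured compounds shown here, in a functional assay on HeLa cells (Homo sapiens) for inhibition, read by MTT assay, with a stated time of 48 h (on this read-out higher numbers stand for weaker inhibition and lower numbers for stronger inhibition), compound 3 `CCOC(=O)C1=C(N/C=N/c2ccc([N+](=O)[O-])cc2)Nc2[nH]nc(C)c2C1c1ccc(N(C)C)cc1` gives 57800 nM, the highest of the three numbers measured so far and so the weakest inhibition seen. Compound 1 `CCOC(=O)C1=C(N/C=N/c2nnc(S(N)(=O)=O)s2)Nc2[nH]nc(C)c2C1c1ccc(N(C)C)cc1` gives 26300 nM in this assay, and compound 2 `CCOC(=O)C1=C(NN=C(C(C)=O)C(C)=O)Nc2[nH]nc(C)c2C1c1ccc(N(C)C)cc1` gives 17000 nM. The move from compound 3 to compound 4 `CCOC(=O)C1=C(NN=C(C#N)C#N)Nc2[nH]nc(C)c2C1c1ccc(N(C)C)cc1` is this: a group of 6 heavy atoms (3 carbon, 3 nitrogen; no ring) in place of a group of 11 heavy atoms (7 carbon, 2 nitrogen, 2 oxygen; one six-membered aromatic ring of carbon only), on an amine nitrogen. For the measured compounds named here, two measured steps touch on it. The step from compound 1 to compound 3 was a 2.2-fold higher number from compound 1 to compound 3 (0.34 log units; beyond the scatter), and the step from compound 2 to compound 3 was a 3.4-fold higher number from compound 2 to compound 3 (0.53 log units; beyond the scatter); both show compound 3 standing at the weak end, with a no-ring group on the amine nitrogen in compound 2 giving a lower number than the aromatic ring in compound 3. Compound 4 also carries a small no-ring group on that nitrogen, with two nitrile groups on a double bond in place of the two acetyl groups of compound 2, so the nearest comparison is compound 2, and a lower number than compound 3 is expected, of a modest size. Compound 4 is therefore expected to show a step of a 3.4-fold lower number from compound 3 to compound 4 (0.53 log units; beyond the scatter) in this assay. The estimate for compound 4 is 17000 nM, with a likely range from 7000 nM to 40000 nM.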

Compound 4, half-maximal inhibitory concentration: 15200 nM
Beside the measured number, compound 4's estimate is 1.1-fold (0.05 log units) above it; the range from low to high includes it.
By their numbers in this assay, from the lowest: compounds 4, 2 and 1 (each within the scatter of the next); then compound 3.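

In this assay, among the compounds shown here, putting the no-ring group of compound 4 on the amine nitrogen in place of the group with a six-membered aromatic ring gives a 3.8-fold lower number from compound 3 to compound 4 (0.58 log units; beyond the scatter), so compound 2 is no longer the only no-ring example to part from compound 3. Exchanging the acetyl groups for nitrile groups makes no readable difference, with a 1.1-fold lower number from compound 2 to compound 4 (0.05 log units; within the scatter), so this position tolerates that change in this assay. The step of a 1.7-fold lower number from compound 1 to compound 4 (0.24 log units; within the scatter) also lies within the scatter even though compound 1 carries a five-membered aromatic ring, so having a ring here does not by itself go with a higher number, and only compound 3 stands apart as the weakest of the four.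

Nothing measured here explains why compound 3 differs from the other three. Going by these compounds, it remains open whether a plain phenyl group, a longer carbon chain, an amine or a carboxylic acid on this amine nitrogen would stay level with compounds 1, 2 and 4 or move towards compound 3.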